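A few compounds are considered here, and "the series" means these few. Any claim that something is new, unique, unknown or untested is made for them only; others in the source may bear on it.

Compound 1 `O=S(=O)(/C=C/c1ccc(O)c(O)c1)CCC1CCCCC1`: 9800 nM
Compound 2 `O=S(=O)(/C=C/c1ccc(O)c(O)c1)CC1CC1`: 10500 nM
Compound 3 `CCCCCCCS(=O)(=O)/C=C/c1ccc(O)c(O)c1`: 7100 nM

All three compounds were tested in a functional assay, read by fluorescence and spectrophotometry, with a stated time of 1 h; a higher number here means that more compound is needed for the effect, a lower number that less compound is needed. Compound 3 cannot be separated from the other two, as its gaps to them are a 1.4-fold lower number from compound 1 to compound 3 (0.14 log units; within the scatter) and a 1.5-fold lower number from compound 2 to compound 3 (0.17 log units; within the scatter). The next compound, compound 4 `C=CCCCCCS(=O)(=O)/C=C/c1ccc(O)c(O)c1`, differs from compound 3 only at the end of the chain: vinyl in place of ethyl on a saturated chain carbon, five bonds along the chain from a sulfonyl sulfur. This places vinyl in place of ethyl on a saturated chain carbon, five bonds along the chain from a sulfonyl sulfur.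

For the measured compounds named here, no measured step covers this exact change, so the evidence is indirect. Exchanges of whole groups on the chain gave only those two steps and a 1.1-fold higher number from compound 1 to compound 2 (0.03 log units; within the scatter), and all three stay within the scatter. The smaller change in compound 4 is therefore expected to produce no step beyond the scatter in this assay. The expected step is a 1.1-fold higher number from compound 3 to compound 4 (0.02 log units; within the scatter). For compound 4 the estimated value is 7500 nM, with an expected range of 4000 nM to 14000 nM.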

Compound 4, half-maximal effective concentration: 7100 nM
For compound 4 the middle estimate is 1.1-fold (0.02 log units) above the measured one, and the stated range covers the measured number.
By their numbers in this assay, from the lowest: compounds 3, 4, 1 and 2 (each within the scatter of the next).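

For the compounds shown here, compound 4 is the first change confined to the far end of the chain, and in this assay it gives no change at the digits printed from compound 3 to compound 4 (within the scatter) at this place, five bonds along the chain from a sulfonyl sulfur. The hex-5-en-1-yl chain also cannot be separated from the chains carrying a ring, with a 1.5-fold lower number from compound 2 to compound 4 (0.17 log units; within the scatter) and a 1.4-fold lower number from compound 1 to compound 4 (0.14 log units; within the scatter) as its gaps, so a double bond at the chain end adds no distinction among these four compounds. Nothing available explains this outcome.

Every step shown lies within the scatter, so it remains open whether any change on this chain can shift the number beyond it. A carboxylic acid or an amine at the chain end, or a longer chain, would test this.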